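Swapping an Oxazole Amide for a Fluorobenzamide

A few compounds are considered here, and "the series" means these few. Any claim that something is new, unique, unknown or untested is made for them only; others in the source may bear on it.

Compound 3, `COc1ccc(-c2cnc(NC(=O)c3ccno3)n2C)cc1`, carries a 1,2-oxazol-5-yl group on its amide carbonyl. In a toxicity assay on THP-1 cells (Homo sapiens) for inhibition (a lower number here means that less compound is tolerated, a higher number that more compound is tolerated), compound 3 reaches only a limit of the assay, > 100000 nM. Compound 1, `COc1ccc(-c2nc3ncc(-c4ccc(F)cc4)cc3[nH]2)cc1`, likewise gives only a limit in this assay, > 100000 nM. Compound 2, `Cn1cc(-c2ccccc2)nc1NC(=O)c1ccc(F)cc1`, also stops at a limit, > 50000 nM. Among the measured compounds shown here, two of the three values thus sit at the limit of > 100000 nM in this assay, at which 2 of the 3 values shown sit, and one at the limit of > 50000 nM in this assay, at which 1 of the 3 values shown sits; since none of the three compounds yields a number, compound 3 cannot be ordered against the others, and no step between measured compounds can be drawn.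

Compound 4, `COc1ccc(-c2cnc(NC(=O)c3ccc(F)cc3)n2C)cc1`, is the compound still to be measured. It differs from compound 3 in a single place: 4-fluorophenyl in place of 1,2-oxazol-5-yl on a carbonyl carbon. Compound 2 already carries a 4-fluorophenyl on its amide carbonyl and shows only a limit, so the shown values give no sign that this change lowers the tolerated concentration. No step beyond the scatter is expected from compound 3 to compound 4, which is the expected a number no higher from compound 3 to compound 4 (the limit leaves the size open). Compound 4 is expected to give 100000 nM, with a range from 30000 nM to 300000 nM, and most likely the assay will again report a limit rather than a number.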

Compound 4, half-maximal cytotoxic concentration: >= 50000 nM
Compound 4 was reported as a limit (the forecaster's own chance of this, stated with the estimate: 85%); the middle value does not contradict the limit.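

Compound 3 and compound 4 both stop at a limit in this assay, so no step can be read between them for 4-fluorophenyl in place of 1,2-oxazol-5-yl on the carbonyl carbon. The compounds shown leave open at what concentration any of them reaches its half-maximal cytotoxic effect, and whether this swap shifts that concentration at all.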